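This account rests on a few compounds, and the source may have more. Where it says the series, first, only, none or still open, it means among the compounds named here.

In a physicochemical assay for permeability, using PAMPA (on this read-out lower numbers stand for lower permeability and higher numbers for higher permeability), compound 1 `N[C@H]1CC[C@H](Nc2ccc3ncc(-c4cnc(Nc5ccccc5)nc4)n3n2)CC1` gives 2 nm/s, while compound 2 `Cc1ccc2ncc(-c3cnc(Nc4ncccc4F)nc3)n2n1` gives 138 nm/s. Among the compounds with values here, compound 2 therefore holds the higher of the two numbers so far, and the gap between them lies well beyond the usual scatter of repeated measurements.

The next compound to be measured is compound 3 `CN1CC[C@H](Nc2ccc3ncc(-c4cnc(Nc5ncccc5F)nc4)n3n2)C1`. It carries (1-methylpyrrolidin-3-yl)amino in place of the methyl of compound 2, on an aromatic carbon of a six-membered aromatic ring with 2 nitrogen ((1-methylpyrrolidin-3-yl)amino in place of methyl on an aromatic carbon). A small group thus gives way to a much larger one that brings a ring and a defined stereocentre.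

Within the data shown here, no two measured compounds differ in only one place, so no measured step shows directly what this kind of swap does. The closest guide is compound 1, which also has a non-aromatic ring joined through an amino group and stands at 2 nm/s. A fall beyond the scatter is therefore expected in this assay, and the estimated size is a 9.2-fold lower number from compound 2 to compound 3 (0.96 log units; beyond the scatter). For compound 3, the estimated value is 15 nm/s, with an expected range from 3 nm/s to 60 nm/s.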

Compound 3, apparent permeability: 2 nm/s
Estimate against measurement, compound 3: 7.5-fold (0.88 log units) above; the whole stated range lies above it.
By their numbers in this assay, from the lowest: compounds 1 and 3 (each within the scatter of the next); then compound 2.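

Swapping methyl for (1-methylpyrrolidin-3-yl)amino on this aromatic carbon gives, in this assay, a 69-fold lower number from compound 2 to compound 3 (1.84 log units; beyond the scatter), a large step and the first measured change made in one place only. It shows that the read-out is far from indifferent to what sits at this position. However, the entering group brings a non-aromatic ring, a hydrogen-bond donor, hydrogen-bond acceptors and a defined stereocentre all at once, so the step belongs to the group as a whole and not to any one of these features. No measurement is at hand that explains the fall.

The compounds shown leave open which part of the group carries the step: a plain amino group, a methylamino group or a cyclopentylamino group at the same carbon would begin to separate the linking nitrogen, the ring and the ring nitrogen. They also leave open whether the opposite arrangement at the stereocentre, or an open chain such as 2-(dimethylamino)ethylamino, would give a similar number on this read-out.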